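The source may hold more compounds than are shown below. What is called first, only, known or untested is meant among the compounds shown, and "the series" means these compounds.

For the measured compounds named here, compound 1 `C/C(=N\OC(=O)C(C)(C)C)c1ccc(Sc2cc(F)cc(C3CCOCC3)c2)cc1` is one of three compounds measured in a functional assay (blood) for inhibition, with Homo sapiens as the target (on this read-out higher numbers stand for weaker inhibition and lower numbers for stronger inhibition), where compound 1 gives 40 nM. Compound 3 `COC1(c2cc(F)cc(Sc3ccc4c(c3)OCC/C4=N\OCC#N)c2)CCOCC1` gives 40 nM, level with compound 1 at the digits shown and within the scatter, so these two together stand at the lowest numbers of the three. Compound 2 `CO[C@]1(c2cnc(S(=O)(=O)c3ccc(/C(C)=N/OCC#N)cc3)s2)CCO[C@@H](C)C1` gives 140 nM, a higher number than compound 1 and beyond the scatter.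

Compound 4 `C/C(=N\OC(=O)N(C)C)c1ccc(Sc2cc(F)cc(C3CCOCC3)c2)cc1` has not yet been measured. It differs from compound 1 in one place: dimethylamino in place of tert-butyl on a carbonyl carbon. Going by the values given here, no pair of measured compounds shares this change, so the data show nothing about what it does on its own. The expectation for compound 4 in this assay therefore rests on compound 1 and its value 40 nM alone, with a wide allowance for the unknown change. Compound 4 is expected to give 60 nM, within a range from 20 nM to 200 nM. The step of a 1.5-fold higher number from compound 1 to compound 4 (0.18 log units; within the scatter) is expected to be small, toward a somewhat higher number, and may well lie within the scatter.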

Compound 4, half-maximal inhibitory concentration: 2610 nM
Beside the measured number, compound 4's estimate is 44-fold (1.64 log units) below it; the measured number lies above the stated range.
By their numbers in this assay, from the lowest: compounds 1 and 3 (each within the scatter of the next); then compound 2; then compound 4.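

In this assay, dimethylamino in place of tert-butyl on a carbonyl carbon gives a 65-fold higher number from compound 1 to compound 4 (1.81 log units; beyond the scatter), a large step and the only change in one place that can be read among these compounds. It shows that this position is far from indifferent to the group it carries, even though neither group has a ring, a net charge, or a hydrogen-bond donor or acceptor by the counts. Nothing measured on these compounds accounts for the size of this step.

The compounds shown leave open whether the step follows from the nitrogen of dimethylamino or from the loss of tert-butyl itself. An isopropyl or a methoxy group on the same carbonyl carbon could tell these apart, and a cyclopropyl group would extend the comparison.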